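A few compounds are considered here, and "the series" means these few. Any claim that something is new, unique, unknown or untested is made for them only; others in the source may bear on it.

Compound 1 `COC(=O)c1c(-c2ccc(OC)cc2)oc2ccccc2c1=O` in a functional assay on HT-29 cells (Homo sapiens) for cytotoxicity, read by MTT assay, with a stated time of 6 days (a higher number here means that more compound is needed for the effect, a lower number that less compound is needed), gives > 25 ug/mL, which is a limit of the assay.
Compound 2 `COC(=O)c1c(-c2ccc([N+](=O)[O-])cc2)oc2ccccc2c1=O` gives > 25 ug/mL, also a limit of the assay.
Compound 3 `COC(=O)c1c(-c2ccc(O)cc2)oc2ccccc2c1=O` gives > 25 ug/mL, again a limit of the assay.

All three values thus sit at the limit of > 25 ug/mL in this assay, at which 3 of the 3 values shown sit, so none of the steps between them can be read. The change from compound 1 to compound 3 is hydrogen in place of methyl on an oxygen on an aromatic ring, and its step that the two limits leave unreadable from compound 1 to compound 3 stays unreadable. Compound 4 `O=C(O)c1c(-c2ccc([N+](=O)[O-])cc2)oc2ccccc2c1=O` is not yet measured and arises from compound 2 by hydrogen in place of methyl on an oxygen next to a carbonyl group. The two cores differ by nitro in place of methoxy on an aromatic carbon. The change to compound 4 is the same kind of change as that to compound 3, not the same: in compound 3 the oxygen sits on an aromatic ring with aromatic carbon as its other neighbour, whereas in compound 4 it sits next to a carbonyl group with carbonyl carbon as its other neighbour. In this assay the step to compound 4 is expected to be a step that the limit leaves unreadable from compound 2 to compound 4. This expectation rests on compound 2 showing only a limit, > 25 ug/mL. Compound 4 is therefore estimated at 30 ug/mL, within 10 ug/mL to 100 ug/mL, most likely reported again only as a limit.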

Compound 4, concentration for half-maximal effect: > 25 ug/mL
Compound 4: a limit, no number; the forecaster's own chance of this, stated with the estimate: 80%; the middle value is on the limit's open side.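

In this assay compound 4 gives > 25 ug/mL, which is a limit of the assay and not a number. The step from compound 2 to compound 4 therefore cannot be read, and no other new step arises, since all four compounds share one limit: the limit of > 25 ug/mL in this assay, at which 4 of the 4 values shown sit.

The compounds shown leave open how far apart these four compounds truly lie, and whether any change to the shared core would give a number rather than a limit.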